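The compounds below may be only part of what the source reports. "The series", "measured", "known", "first", "only" and "open" are said of these compounds alone.

Working notes on the series. Compound 1 `O=C(Nc1cc(-c2ccccc2)nn1-c1ccccc1)c1ccc(OC(F)(F)F)cc1` carries a trifluoromethoxy group on the aromatic ring attached to the carbonyl; in an assay on HEK293 cells for displacement of a labelled ligand from metabotropic glutamate receptor 5 (Rattus norvegicus) (a higher number here means a weaker inhibitor, a lower number a stronger inhibitor), compound 1 gives 265 nM. Compound 2 `O=C(Nc1cc(-c2ccccc2)nn1-c1ccccc1)c1ccc(C(F)(F)F)cc1` carries trifluoromethyl in its place, and in this assay compound 2 gives 990 nM. Among the measured compounds shown here, the one measured step, a 3.7-fold higher number from compound 1 to compound 2 (0.57 log units; beyond the scatter), puts compound 2 at the highest number of the two values so far, with compound 1 as its only neighbour.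

Compound 3 `Cc1ccc(C(=O)Nc2cc(-c3ccccc3)nn2-c2ccccc2)cc1C` awaits measurement. Its change from compound 2 is 3,4-dimethylphenyl in place of 4-(trifluoromethyl)phenyl on a carbonyl carbon. For the measured compounds named here, no recorded step covers this exchange: the single step available, a 3.7-fold higher number from compound 1 to compound 2 (0.57 log units; beyond the scatter), swaps trifluoromethoxy for trifluoromethyl on the same ring and carries no information on methyl groups. The two known values sit within a modest window, so a step of at most modest size in this assay is expected, in either direction, with a slight lean toward a lower number and wide uncertainty. Compound 3 is estimated at 700 nM, range 200 nM to 2500 nM, an expected step of a 1.4-fold lower number from compound 2 to compound 3 (0.15 log units; within the scatter).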

Compound 3, inhibition constant: 430 nM
For compound 3 the middle estimate is 1.6-fold (0.21 log units) above the measured one, and the stated range covers the measured number.
By their numbers in this assay, from the lowest: compounds 1 and 3 (each within the scatter of the next); then compound 2.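

Among the compounds shown here, the exchange of 4-(trifluoromethyl)phenyl for 3,4-dimethylphenyl on the carbonyl carbon gives a 2.3-fold lower number from compound 2 to compound 3 (0.36 log units; beyond the scatter), the first step to replace the fluorinated group with one made of carbon only, and the first to show that this position accepts such a group with no rise in the number. In this assay compound 3 gives 430 nM, within the scatter of compound 1 at 265 nM, so among these three compounds fluorine on this ring is not required to reach the lower part of the measured range, and only compound 2 stands apart from the other two. No measurement available here bears on what lies behind this step.

Going by these compounds, whether a single methyl group would give a number like that of the two methyl groups together remains open, and so does how the position responds to an amine, a carboxylic acid or a longer chain on this ring. The compounds shown also all keep the shared core unchanged, leaving the contribution of any other part of the molecule unresolved.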